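Triazole series: trimethoxyphenyl core with chlorophenacyl sulfanyl arm

This account rests on a few compounds, and the source may have more. Where it says the series, first, only, none or still open, it means among the compounds named here.

Measured so far in a functional assay on MKN-45 cells (Homo sapiens) for cytotoxicity, read by MTT assay, with a stated time of 48 h; a higher number here means a weaker inhibitor, a lower number a stronger inhibitor:
Compound 1 `CCCc1nnc(SCC(=O)c2ccc(Cl)cc2)n1N1C(=O)c2ccccc2C1=O`. In this assay compound 1 gives > 200000 nM, a limit of the assay and not a number.
Compound 2 `C#CCSc1nnc(-c2cc(OC)c(OC)c(OC)c2)n1N1C(=O)c2ccccc2C1=O`. In this assay compound 2 gives > 200000 nM, likewise a limit.

Within the data shown here, compound 2 therefore stands nowhere on a numeric scale: its value is a limit only, and the one further value shown is a limit as well, both sitting at the limit of > 200000 nM in this assay, at which 2 of the 2 values shown sit. Among the measured compounds shown here, no step between measured compounds can be stated.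

Compound 3 `COc1cc(-c2nnc(SCC(=O)c3ccc(Cl)cc3)n2N2C(=O)c3ccccc3C2=O)cc(OC)c1OC` differs from compound 2 by (4-chlorophenyl)carbonyl in place of ethynyl on a saturated chain carbon bound to a sulfur, that is propargylsulfanyl to (((4-chlorophenyl)carbonyl)methyl)sulfanyl. For the measured compounds named here, the entering arm is the one compound 1 carries, and compound 1 reaches only a limit. The step in this assay from compound 2 to compound 3 is expected to be a step that the limit leaves unreadable from compound 2 to compound 3, none beyond the scatter. Compound 3 is estimated at 250000 nM, within 60000 nM to 1000000 nM, most probably reported again as a limit.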

Compound 3, half-maximal inhibitory concentration: 26600 nM
The estimate for compound 3 lay 9.4-fold (0.97 log units) above the measured number; the whole stated range lies above it.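

In this assay, (4-chlorophenyl)carbonyl in place of ethynyl on a saturated chain carbon bound to a sulfur gives an at least 7.5-fold lower number from compound 2 to compound 3 (0.87 log units; beyond the scatter). The (((4-chlorophenyl)carbonyl)methyl)sulfanyl arm is not enough alone: with that arm held constant, 3,4,5-trimethoxyphenyl in place of propyl on an aromatic carbon gives an at least 7.5-fold lower number from compound 1 to compound 3 (0.87 log units; beyond the scatter), so among these compounds a number appears only where the arm and the 3,4,5-trimethoxyphenyl group occur together. Both steps are bounds rather than sizes, because compound 1 and compound 2 each rest on a limit: the limit of > 200000 nM in this assay, at which 2 of the 3 values shown sit.

Among these compounds, compound 3 is the only compound with a number, so the true size of either step remains open. Also open, from the compounds shown here alone, is whether an amine or a carboxylic acid in place of the 4-chlorophenyl group would retain this activity.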